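Replacing 3-(Trifluoromethyl)phenyl with 2,6-Difluorophenyl at a Carbonyl

This account rests on a few compounds, and the source may have more. Where it says the series, first, only, none or still open, it means among the compounds named here.

Measured compounds: compound 1 `CN(C(=O)NC(=O)c1ccc(F)c(F)c1)c1nc(C(F)(F)F)c(C(=O)N/N=C/c2cc(C(F)(F)F)cc(C(F)(F)F)c2)s1` gives 2.61 ug/mL in a functional assay on MCF7 cells (Homo sapiens) for inhibition, read by MTT assay, with a stated time of 72 h; a lower number here means a stronger inhibitor, a higher number a weaker inhibitor. Compound 3 `CN(C(=O)NC(=O)c1cccc(C(F)(F)F)c1)c1nc(C(F)(F)F)c(C(=O)N/N=C/c2cc(C(F)(F)F)cc(C(F)(F)F)c2)s1` gives 6.08 ug/mL in this assay. Compound 2 `CN(C(=O)NC(=O)c1ccc(C(F)(F)F)cc1)c1nc(C(F)(F)F)c(C(=O)N/N=C/c2ccc(C(F)(F)F)cc2)s1` reaches only a limit of this assay, > 100 ug/mL.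

Compound 3 carries the highest of the two numbers; its nearest neighbour is compound 1, with a step of a 2.3-fold higher number from compound 1 to compound 3 (0.37 log units; beyond the scatter). Compound 4 `CN(C(=O)NC(=O)c1c(F)cccc1F)c1nc(C(F)(F)F)c(C(=O)N/N=C/c2cc(C(F)(F)F)cc(C(F)(F)F)c2)s1` differs from compound 3 in one place: 2,6-difluorophenyl in place of 3-(trifluoromethyl)phenyl on a carbonyl carbon. Among the measured compounds shown here, only one measured step touches this position, the one from compound 1 to compound 3, where a difluorophenyl on the same carbonyl gave the lower number by a 2.3-fold higher number from compound 1 to compound 3 (0.37 log units; beyond the scatter), a modest step. For the measured compounds named here, compound 4 returns to a difluorophenyl at that carbonyl, though with its fluorines placed as 2,6-difluorophenyl, a pattern no measured compound shows. Compound 2 sits at a limit of > 100 ug/mL in this assay, at which 1 of the 3 values shown sits, and says nothing about this position. Compound 4 is therefore expected to fall close to compound 1 and compound 3, with a step of a 1.5-fold lower number from compound 3 to compound 4 (0.18 log units; within the scatter) toward a lower number, not far beyond the scatter. The expected value for compound 4 in this assay is 4 ug/mL, within a range from 1.5 ug/mL to 11 ug/mL.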

Compound 4, half-maximal inhibitory concentration: 6.85 ug/mL
For compound 4 the middle estimate is 1.7-fold (0.23 log units) below the measured one, within the range that was stated.
By their numbers in this assay, from the lowest: compound 1; then compounds 3 and 4 (each within the scatter of the next). At a limit, above all of these: compound 2.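

In this assay, the exchange of 3-(trifluoromethyl)phenyl for 2,6-difluorophenyl on the carbonyl carbon is a 1.1-fold higher number from compound 3 to compound 4 (0.05 log units; within the scatter), so these two groups cannot be told apart at this position. A difluorophenyl on this carbonyl does not by itself go with the lower number of compound 1: with only the placing of the two fluorines changed, the exchange of 3,4-difluorophenyl for 2,6-difluorophenyl is a 2.6-fold higher number from compound 1 to compound 4 (0.42 log units; beyond the scatter), so that 3,4-difluorophenyl stands apart from both other groups here, though only by modest steps. No measurement shown gives a reason for these differences.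

All the groups shown at this carbonyl are phenyl rings bearing fluorine or trifluoromethyl, so it stays open how an unsubstituted phenyl, a methoxyphenyl or a pyridine ring would compare with them in this assay. Also open, going by these compounds, is whether the same steps would appear if the other aryl group of the shared core carried a methoxy group or an amine in place of its trifluoromethyl groups.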